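Rat Microsomal Half-Life of a Dimethoxyphenyl Analogue

This account rests on a few compounds, and the source may have more. Where it says the series, first, only, none or still open, it means among the compounds named here.

Compound 1 `Cc1oc(-c2ccc(Cl)cc2)nc1CN1CCC(C(=O)NCCCN2C[C@H](C)C[C@H](C)C2)CC1` and compound 2 `Cc1ccc(-c2nc(CN3CCC(C(=O)NCCCN4C[C@H](C)C[C@H](C)C4)CC3)c(C)o2)cc1` share a common core. In an ADME assay on microsomes from liver (Rattus norvegicus) for metabolic stability, read by LC-MS, using NADPH, at 37 degrees C (on this read-out lower numbers stand for a shorter-lived compound and higher numbers for a longer-lived compound), compound 1 gives > 0.5 h, which is a limit of the assay rather than a number. In this assay compound 2 also gives > 0.5 h, again a limit. Going by the values given here, the only measured step, a step that the two limits leave unreadable from compound 1 to compound 2, therefore cannot be sized, since both of its values sit at the limit of > 0.5 h in this assay, at which 2 of the 2 values shown sit.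

Compound 3 `COc1ccc(-c2nc(CN3CCC(C(=O)NCCCN4C[C@H](C)C[C@H](C)C4)CC3)c(C)o2)cc1OC` has not yet been measured. It differs from compound 2 by 3,4-dimethoxyphenyl in place of 4-methylphenyl on an aromatic carbon. Among the compounds with values here, no measured step involves the entering group, and the one step available does not read, so there is nothing to fix the direction or size of the change from compound 2 to compound 3; compound 2 itself stands only as a limit. In this assay compound 3 is estimated to give 0.4 h, with an expected range from 0.15 h to 1 h. The step from compound 2 to compound 3 is thus expected to be an at least 1.2-fold lower number from compound 2 to compound 3 (0.09 log units; that floor lies within the scatter).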

Compound 3, half-life: > 0.5 h
Compound 3 ended at the assay's limit; the forecaster's own chance of this, stated with the estimate: 45%; at least 1.2-fold (0.09 log units) between middle value and limit.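

Compound 3, like compound 1 and compound 2, gives a limit and not a number in this assay, so no step among these three compounds can be read: the limit of > 0.5 h in this assay, at which 3 of the 3 values shown sit.

The compounds shown leave open how long each one actually lasts, and whether the 4-chlorophenyl, 4-methylphenyl and 3,4-dimethoxyphenyl groups differ at all in this assay.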